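Swapping a cyclohexylmethyl amine chain for a pyridinyl one

The source may report more compounds than this note shows. Statements on the series, on what has been measured and on what is new or still open speak of the compounds shown alone.

Measured in a functional assay on cells for antagonist activity at C-X-C chemokine receptor type 4 (Homo sapiens), read by fluorescence and calcium flux, with stated times of 25 min and 90 s; on this read-out lower numbers stand for stronger inhibition and higher numbers for weaker inhibition:
compound 1, `c1ccc2c(c1)CN[C@@H](CN(CCCCNCC1CCCCC1)[C@H]1CCCc3cccnc31)C2`: 158 nM
compound 2, `c1ccc2c(c1)CN[C@@H](CN(Cc1ccc(CNCc3ccncc3)cc1)[C@H]1CCCc3cccnc31)C2`: 134 nM

Compound 1 gives the higher of the two numbers, but its nearest neighbour, compound 2, sits within the usual scatter of it, so the two cannot be ranked. Compound 3, `C(=C/CN(C[C@H]1Cc2ccccc2CN1)[C@H]1CCCc2cccnc21)\CNCc1cccnc1`, is not yet measured. It differs from compound 1 in one place: a group of 11 heavy atoms (9 carbon, 2 nitrogen; one six-membered aromatic ring with 1 hetero atom) in place of a group of 11 heavy atoms (10 carbon, 1 nitrogen; one six-membered non-aromatic ring of carbon only), on a saturated chain carbon bound to an amine nitrogen. The chain that enters carries one six-membered aromatic ring with one hetero atom and one double bond outside aromatic rings, while the chain that leaves carries one six-membered non-aromatic ring of carbon only. Compound 2, which also carries an aromatic amine-bearing chain on the shared core, shows a number close to compound 1, so the step of a 1.3-fold lower number from compound 1 to compound 3 (0.12 log units; within the scatter) is expected to stay within the scatter, if anything slightly downward. Compound 3 is estimated at 120 nM, with a range from 50 nM to 300 nM.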

Compound 3, half-maximal inhibitory concentration: 92.8 nM
Compound 3: the middle estimate sits 1.3-fold (0.11 log units) above what was measured; the measured number falls inside the stated range.
By their numbers in this assay, from the lowest: compounds 3, 2 and 1 (each within the scatter of the next).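

In this assay, replacing the 3-((cyclohexylmethyl)amino)propyl group with a chain of the same heavy-atom count, carrying a six-membered aromatic ring with one hetero atom and a double bond outside aromatic rings, gives a 1.7-fold lower number from compound 1 to compound 3 (0.23 log units; within the scatter). At this place, on a saturated chain carbon bound to an amine nitrogen, the carbon-only non-aromatic ring is therefore not required to keep the number within the scatter of compound 1, and the chain can carry a double bond. Nothing measured here gives a cause for this outcome.

The ring and the double bond entered together, so a single step cannot separate them. The compounds shown leave open what a phenyl ring would give in place of the hetero-atom ring, and what a fully saturated chain bearing the same aromatic ring would give.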